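Shifting a Methoxy Group: Expected Effect on Cytotoxicity

The source may report more compounds than this note shows. Statements on the series, on what has been measured and on what is new or still open speak of the compounds shown alone.

Three measured compounds share one core and differ only in the group attached to an aromatic nitrogen. Compound 1 `Oc1cc(C(F)(F)F)ccc1-c1nc(-c2ccccc2O)n(-c2ccc(F)cc2)n1` in a functional assay on PC-12 cells (Rattus norvegicus) for cytotoxicity, read by MTT assay, with stated times of 2 h and 24 h, tested at 1 uM (on this read-out higher numbers stand for a stronger effect at the one concentration tested and lower numbers for a weaker effect), gives 67.2%. Compound 2 `Oc1cc(C(F)(F)F)ccc1-c1nc(-c2ccccc2O)n(-c2ccc(Cl)cc2)n1` gives 68% in this assay, and compound 3 `COc1ccc(-n2nc(-c3ccc(C(F)(F)F)cc3O)nc2-c2ccccc2O)cc1` gives 69%. Compound 3 holds the highest of the three numbers, yet its gap to compound 2, the nearest, and to compound 1, the furthest, both fall within the scatter, so no real ordering can be claimed among them.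

The steps between them are all small: a number 0.8 percentage points higher from compound 1 to compound 2 (within the scatter), a number 1.8 percentage points higher from compound 1 to compound 3 (within the scatter) and a number 1 percentage points higher from compound 2 to compound 3 (within the scatter). Each swaps the group on that same aromatic nitrogen without moving the read-out beyond the scatter.

Compound 4 `COc1ccccc1-n1nc(-c2ccc(C(F)(F)F)cc2O)nc1-c1ccccc1O` has the same atoms as compound 3, joined differently: 2-methoxyphenyl in place of 4-methoxyphenyl on an aromatic nitrogen. Among the compounds with values here, no measured step moves a methoxy group from one place on a ring to another, so the three steps above are the only guide, and they point to the read-out being insensitive to what sits on this nitrogen. The step from compound 3 to compound 4 is therefore expected to be a number 1 percentage points lower from compound 3 to compound 4 (within the scatter), nothing beyond the scatter. Compound 4 is estimated at 68% in this assay, with an expected range from 58% to 78%.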

Compound 4, a percentage reported as activity, at one concentration (the size of the read-out at that concentration, not a potency): 70.7%
Compound 4: the middle estimate sits 2.7 percentage points below what was measured; the measured number falls inside the stated range.
By their numbers in this assay, from the lowest: compounds 1, 2, 3 and 4 (each within the scatter of the next).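

Moving the methoxy group around the ring is a different kind of change from swapping one group for another, and in this assay it gives a number 1.7 percentage points higher from compound 3 to compound 4 (within the scatter). Compared with the halogen-bearing rings, the new 2-methoxyphenyl group gives a number 2.7 percentage points higher from compound 2 to compound 4 (within the scatter) and a number 3.5 percentage points higher from compound 1 to compound 4 (within the scatter), so the insensitivity seen so far at this aromatic nitrogen now extends from the identity of the group to where the methoxy sits on its ring, at least for these two placements. No measurement shown offers an explanation for this lack of separation among the four compounds.

From the compounds shown here alone, it remains open whether a group of a different kind on this ring, such as an amine, a carboxylic acid or a longer chain like butoxy in place of methoxy, would move the read-out beyond the scatter. Also open, going by these compounds, is whether these four compounds would separate at other concentrations, since a single concentration shows the size of an effect and not a potency, and whether changes to the trifluoromethyl or hydroxy groups of the shared core would matter more.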